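Bromo to Chloro: Does Cell Toxicity Shift?

This account rests on a few compounds, and the source may have more. Where it says the series, first, only, none or still open, it means among the compounds named here.

Compound 2 `O=C(CCCCC1CCSS1)NCc1cn(CCCCOc2ccc3cc(-c4ccc(Br)cc4)c(=O)oc3c2)nn1` was tested in a functional assay on PC-12 cells (Rattus norvegicus) for cytotoxicity, read by MTT assay, with stated times of 3 h and 2 h, tested at 20 uM (on this read-out higher numbers stand for a stronger effect at the one concentration tested and lower numbers for a weaker effect), where compound 2 gives 45%. Its neighbour compound 1 `COc1ccc(-c2cc3ccc(OCCCCn4cc(CNC(=O)CCCCC5CCSS5)nn4)cc3oc2=O)cc1` gives 52.3%, and the two differ by a number 7.3 percentage points lower from compound 1 to compound 2 (within the scatter), so they sit together within the scatter. Compound 3 `O=C(CCCCC1CCSS1)NCc1cn(CCCCOc2ccc3cc(-c4ccc(Cl)cc4)c(=O)oc3c2)nn1` is not yet measured; it differs from compound 2 by chloro in place of bromo on an aromatic carbon. Going by the values given here, the only measured step, bromo in place of methoxy at the same aromatic carbon, barely moved the read-out, so no step beyond the scatter is expected in this assay. Compound 3 is therefore estimated at 46%, between 33% and 59%. That estimate means a step of a number 1 percentage points higher from compound 2 to compound 3 (within the scatter) is expected.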

Compound 3, a percentage reported as activity, at one concentration (the size of the read-out at that concentration, not a potency): 68.4%
For compound 3 the middle estimate is 22.4 percentage points below the measured one, outside the stated range (above it).
By their numbers in this assay, from the lowest: compounds 2 and 1 (each within the scatter of the next); then compound 3.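

Replacing one halogen with another at this aromatic carbon, para to a large group, can clearly shift the read-out in this assay: the change to chloro gives a number 23.4 percentage points higher from compound 2 to compound 3 (beyond the scatter). Chloro in place of methoxy gives a number 16.1 percentage points higher from compound 1 to compound 3 (beyond the scatter), so this position is not as insensitive as the first step suggested. No measurement here explains the shift. From the compounds shown here alone, whether fluoro or an amine at this carbon would behave like chloro remains open, as does whether the chloro step would hold with a longer chain.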